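Series notes: pyridyl placement on the biaryl tail

This account rests on a few compounds, and the source may have more. Where it says the series, first, only, none or still open, it means among the compounds named here.

Measured so far:
compound 1, `CCC(C)(C)Cc1c[nH]c(CCc2ccc(-c3ccncc3)cc2)n1`, 103 nM
compound 2, `c1ccc(-c2ccc(CCc3nc(CC4CCCC4)c[nH]3)cc2)nc1`, 103 nM

Both compounds were read in a functional assay on HEK293 cells for agonist activity at Bombesin receptor subtype-3 (Mus musculus), read by luminescence and calcium flux, with a stated time of 10 min; a lower number here means that less compound is needed, a higher number that more compound is needed for the effect. Compound 1 gives 103 nM and compound 2 gives 103 nM; the two numbers are level at the digits shown and the gap between them lies within the usual scatter, so no order between compound 1 and compound 2 can be claimed. For the measured compounds named here, no step between measured compounds is available for a change of the kind now under study.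

The next compound, compound 3, `CCC(C)(C)Cc1c[nH]c(CCc2ccc(-c3cccnc3)cc2)n1`, keeps the same atoms as compound 1 but joins them differently: pyridin-3-yl in place of pyridin-4-yl on an aromatic carbon. Nothing in the two measured values speaks to this change, so the expectation rests on the rule that moving a ring nitrogen within an otherwise unchanged pyridyl group usually gives a modest shift in this assay. The step is expected to be small, if anything toward slightly more compound being needed, and it may well sit within the scatter: a 1.6-fold higher number from compound 1 to compound 3 (0.19 log units; within the scatter). For compound 3 the estimate in this assay is 160 nM, with a range from 50 nM to 500 nM.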

Compound 3, half-maximal effective concentration: 97 nM
For compound 3 the middle estimate is 1.6-fold (0.22 log units) above the measured one; measured number inside the range.
By their numbers in this assay, from the lowest: compounds 3, 1 and 2 (each within the scatter of the next).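

Moving the ring nitrogen gives the first readable step at this position on the biaryl tail: in this assay, pyridin-3-yl in place of pyridin-4-yl on an aromatic carbon, para to a large group, gives a 1.1-fold lower number from compound 1 to compound 3 (0.03 log units; within the scatter). This change therefore sets no order for compound 1 and compound 3, and the two pyridyl forms cannot be told apart in this assay. No measured evidence bears on the size of this step, so the result stands as an observation only.

From the compounds shown here alone, it remains open whether a plain phenyl ring or a pyrimidine ring at this position would stay close to compound 1 at 103 nM, which would show how far the result depends on the presence or number of ring nitrogens. Also open, going by these compounds, is how the pyridin-2-yl group of compound 2 would read with the side chain of compound 1; compound 2 differs from compound 1 in more than one place, so that pair says nothing about this position alone.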